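Diethylamino for dimethylamino at the assay limit

The compounds below may be only part of what the source reports. "The series", "measured", "known", "first", "only" and "open" are said of these compounds alone.

In a functional assay on cells (Homo sapiens) for antiproliferative activity, read by MTT assay, with a stated time of 48 h (on this read-out lower numbers stand for stronger inhibition and higher numbers for weaker inhibition), compound 3 `CN(C)CCn1c(N)c(-c2nc3ccccc3n2C)c2nc(C#N)c(C#N)nc21` gives no number, only the limit > 50000 nM. Compound 4 `CCN(CC)CCn1c(N)c(-c2nc3ccccc3n2C)c2nc(C#N)c(C#N)nc21` differs from it in a single place: diethylamino in place of dimethylamino on a saturated chain carbon, two bonds along the chain from an aromatic nitrogen. The same exchange links two measured compounds, compound 1 `CN(C)CCn1c(N)c(-c2nc3ccccc3[nH]2)c2nc(C#N)c(C#N)nc21` at 43500 nM and compound 2 `CCN(CC)CCn1c(N)c(-c2nc3ccccc3[nH]2)c2nc(C#N)c(C#N)nc21` at 25400 nM. The other measured step, methyl in place of hydrogen on an aromatic nitrogen, is an at least 1.1-fold higher number from compound 1 to compound 3 (0.06 log units; that floor lies within the scatter). Resting on a 1.7-fold lower number from compound 1 to compound 2 (0.23 log units; within the scatter), a small move towards lower numbers, none beyond the scatter, is expected, and the estimated step is an at least 1.2-fold lower number from compound 3 to compound 4 (0.09 log units; that floor lies within the scatter). Compound 4 is estimated at 40000 nM, with an expected range from 20000 nM to 65000 nM.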

Compound 4, half-maximal inhibitory concentration: > 50000 nM
Compound 4: only a limit was reported; the forecaster's own chance of this, stated with the estimate: 45%; middle value at least 1.2-fold (0.09 log units) from the limit.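

In this assay compound 4 gives > 50000 nM, a limit of the assay, and with compound 3 also at a limit, the step between them cannot be read. Methyl in place of hydrogen on an aromatic nitrogen now has a second reading, on the diethylamino pair: an at least 1.9-fold higher number from compound 2 to compound 4 (0.29 log units; that floor lies within the scatter). Set beside the first reading, this second one shows no established difference between the two cores: the same change on two cores in this assay, an at least 1.1-fold higher number (0.06 log units; that floor lies within the scatter) from compound 1 to compound 3 and an at least 1.9-fold higher number (0.29 log units; that floor lies within the scatter) from compound 2 to compound 4; the limit leaves it open whether they differ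

Going by these compounds, whether diethylamino changes anything once that aromatic nitrogen carries methyl stays open. Also open, on these data alone, is whether a longer chain or a morpholine in place of the amine would bring the methyl compounds to a measurable number.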